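The source may report more compounds than this note shows. Statements on the series, on what has been measured and on what is new or still open speak of the compounds shown alone.

Compound 1 `COc1ncc(-c2ccc3c(c2)NC(=O)CO3)cc1NS(=O)(=O)c1ccc(F)cc1` and compound 3 `COc1ncc(-c2ccc3c(c2)N(c2ccc(Cl)cc2)C(=O)CO3)cc1NS(=O)(=O)c1ccc(F)cc1` share one core, while compound 2 `O=C1COc2ccc(-c3cnc4ccccc4c3)cc2N1` and compound 4 `O=C1COc2ccc(-c3cnc4ccccc4c3)cc2N1c1ccc(Cl)cc1` share another; how the two cores differ is not broken down here. Antiproliferative activity was measured in a functional assay on A-375 cells (Homo sapiens) for antiproliferative activity, read by MTT assay, with a stated time of 72 h; a higher number here means a weaker inhibitor, a lower number a stronger inhibitor. In this assay compound 1 gives 26300 nM and compound 3 gives 24100 nM. For compound 2 only a limit of this assay is known, > 40000 nM. Compound 3 differs from compound 1 by a single change, (4-chlorophenyl in place of hydrogen on an amide-type nitrogen in a ring), and that change made the step of a 1.1-fold lower number from compound 1 to compound 3 (0.04 log units; within the scatter). Compound 4 differs from compound 2 by the same change, (4-chlorophenyl in place of hydrogen on an amide-type nitrogen in a ring). Because the same change made only a 1.1-fold lower number from compound 1 to compound 3 (0.04 log units; within the scatter), the step of a number no higher from compound 2 to compound 4 (the limit leaves the size open) is expected to be of similar size. The value of compound 2 sits at the limit of > 40000 nM in this assay, at which 1 of the 3 values shown sits, so a result at that limit is plausible for compound 4 as well. Compound 4 is therefore estimated at 40000 nM, with a range from 20000 nM to 80000 nM expected.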

Compound 4, half-maximal inhibitory concentration: > 40000 nM
Compound 4: only a limit was reported (the forecaster's own chance of this, stated with the estimate: 70%); the middle value sits exactly at the limit.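

No new step can be read between compound 2 and compound 4, because both results are limits of this assay rather than numbers: the limit of > 40000 nM in this assay, at which 2 of the 4 values shown sit.

The compounds shown leave open whether 4-chlorophenyl in place of hydrogen on the amide-type nitrogen changes antiproliferative activity at all on the core shared by compound 2 and compound 4.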